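This account rests on a few compounds, and the source may have more. Where it says the series, first, only, none or still open, it means among the compounds named here.

Three compounds have been measured in an assay on HEK293 cells for inhibition of N-acylethanolamine-hydrolyzing acid amidase (Homo sapiens), read by fluorescence, with stated times of 10 min and 50 min; on this read-out lower numbers stand for stronger inhibition and higher numbers for weaker inhibition:

Compound 1 `CCCCc1ccc(COC(=O)N[C@H]2CNC2=O)cc1`: 23 nM
Compound 2 `O=C(N[C@H]1CNC1=O)OCc1ccc2c(c1)CCCC2`: 140 nM
Compound 3 `O=C(N[C@H]1CNC1=O)OCCCCc1ccccc1`: 1110 nM

Compound 3 stands highest of the three numbers in this assay. Compound 2 sits below it by a margin beyond the scatter, and compound 1 lies lower still, also beyond the scatter, so compound 3 is the weakest inhibitor of the set. Compound 4 `COc1ccc(CCCCOC(=O)N[C@H]2CNC2=O)cc1` differs from compound 3 by methoxy in place of hydrogen on an aromatic carbon. Among the measured compounds shown here, no measured pair shows this change on its own, so its effect is open. A small gain for compound 4 is expected, with a step of a 2.5-fold lower number from compound 3 to compound 4 (0.39 log units; beyond the scatter) that may reach a little beyond the scatter. Compound 4 is therefore estimated at 450 nM in this assay, within a range from 150 nM to 1500 nM.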

Compound 4, half-maximal inhibitory concentration: 520 nM
Compound 4: the middle estimate sits 1.2-fold (0.06 log units) below what was measured; low and high end bracket the measured number.
By their numbers in this assay, from the lowest: compound 1; then compound 2; then compound 4; then compound 3.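

Methoxy in place of hydrogen on an aromatic carbon, para to a large group, gives a 2.1-fold lower number from compound 3 to compound 4 (0.33 log units; beyond the scatter), a modest step. Among the compounds shown here, this is the first comparison here between compounds that differ in one place, and it shows that this position takes a methoxy without any loss of inhibition. Nothing at hand explains the size of the step. The compounds shown leave open whether another group at this position, such as chlorine, hydroxyl or an amine, would move the number further. They also leave open whether ethoxy, a longer group of the same kind, would add to the step.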